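Paw edema series: from compound 3 to compound 4

The source may hold more compounds than are shown below. What is called first, only, known or untested is meant among the compounds shown, and "the series" means these compounds.

Measured compounds and values:
compound 1 `Cc1occc1-c1nnc2sc(-c3cc(O)nc(O)c3)nn12` gives 16.5%
compound 2 `COc1ccc(Cl)c(-c2nnc3n2NC(c2ccco2)S3)c1` gives 23.1%
compound 3 `COc1ccc(Cl)c(-c2nnc3n2NC(c2ccc([N+](=O)[O-])o2)S3)c1` gives 21.7%

All three numbers come from a functional assay on the whole organism (strain Wistar Albino) for inhibition, with Rattus norvegicus as the target, read by paw edema, with a stated time of 3 h, at a dose of 20 mg/kg; a higher number here means more inhibition at the dose given (going by the name of the read-out), a lower number less inhibition. Compound 3 stands second highest of the three. Its nearest neighbour is compound 2, whose number is higher by an amount within the scatter; its furthest is compound 1, whose number is lower, also within the scatter. On the numbers shown, the three compounds cannot be told apart.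

The compound not yet measured is compound 4 `COc1ccc(Cl)c(-c2nnc3n2NC(c2cccn2C)S3)c1`. It differs from compound 3 in one place: 1-methyl-1H-pyrrol-2-yl in place of 5-nitrofuran-2-yl on a saturated ring carbon.

Going by the values given here, the only measured step that touches this part of the molecule is a number 1.4 percentage points lower from compound 2 to compound 3 (within the scatter). That step changed the same ring and left the read-out in this assay unchanged within the scatter. Among the compounds with values here, the change to compound 4 is of a different kind, since the whole five-membered aromatic ring is swapped, so the one measured step bears on it only loosely. Nothing in the numbers shown points to a step in either direction beyond the scatter.

Compound 4 is therefore expected to give about 21% in this assay, with a range from 11% to 31%. The expected step from compound 3 is a number 0.7 percentage points lower from compound 3 to compound 4 (within the scatter).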

Compound 4, a percentage reported as inhibition, in the whole organism at one dose (the size of the read-out at that dose, not a potency): 18.5%
Estimate against measurement, compound 4: 2.5 percentage points above; the measured number falls inside the stated range.
By their numbers in this assay, from the lowest: compounds 1, 4, 3 and 2 (each within the scatter of the next).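

In this assay the exchange of 5-nitrofuran-2-yl for 1-methyl-1H-pyrrol-2-yl gives a number 3.2 percentage points lower from compound 3 to compound 4 (within the scatter) and the exchange of furan-2-yl for the same group gives a number 4.6 percentage points lower from compound 2 to compound 4 (within the scatter) on the saturated ring carbon. The earlier step changed only a substituent on the furan ring, whereas these two replace the five-membered aromatic ring itself, and compounds 2, 3 and 4 still cannot be told apart, so at this position neither the change of ring nor the loss of the nitro group produces a step beyond the scatter. No measurement at hand accounts for these steps or for their size.

Still open, as far as these compounds go, is whether any group on this carbon moves the number beyond the scatter, for instance a carboxylic acid, an aminomethyl group or a longer alkyl chain in place of the five-membered aromatic ring. Also open, from the compounds shown here alone, is what the methyl on the pyrrole nitrogen contributes, which a comparison with the plain 1H-pyrrol-2-yl group would show.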